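The source may report more compounds than this note shows. Statements on the series, on what has been measured and on what is new or still open speak of the compounds shown alone.

Notes on the series, read in a functional assay on HepG2 cells (Homo sapiens) for antiproliferative activity, read by MTT assay, with a stated time of 48 h; a lower number here means a stronger inhibitor, a higher number a weaker inhibitor.

Compound 1, `Cc1ccc(-n2nncc2CN2C(=O)C3(C(C#N)=C(N)Oc4c3c3nc5ccccc5nc3c3ccccc43)c3ccccc32)cc1Cl`, is measured only as a limit of the assay: in this assay compound 1 gives > 50000 nM. For the measured compounds named here, compound 2, `CCOc1ccccc1-n1nncc1CN1C(=O)C2(C(C#N)=C(N)Oc3c(N)cc4nc5ccccc5nc4c32)c2ccccc21`, is the one member with a number: in this assay compound 2 gives 30500 nM. That is where compound 2 stands on what is shown, the only number in the set, the other entry being a limit, as the line the limit of > 50000 nM in this assay, at which 1 of the 2 values shown sits, records; nothing about an order between the two is taken from this.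

Compound 3, `N#CC1=C(N)Oc2c(N)cc3nc4ccccc4nc3c2C12C(=O)N(Cc1cnnn1-c1c(Cl)cc(Cl)cc1Cl)c1ccccc12`, is not yet measured in this assay. It differs from compound 2 in one place: 2,4,6-trichlorophenyl in place of 2-ethoxyphenyl on an aromatic nitrogen. Going by the values given here, no step between two measured compounds runs through this part of the structure, so the size of the change has no precedent here. The step is expected to be small, within the scatter or at most a little toward a weaker inhibitor, with a 1.2-fold higher number from compound 2 to compound 3 (0.10 log units; within the scatter) as the expected step. Compound 3 is therefore estimated at 38000 nM in this assay, within a range of 12000 nM to 120000 nM, with a real chance that only a limit is reported.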

Compound 3, half-maximal inhibitory concentration: 37800 nM
Compound 3: middle estimate off by 1.0-fold (0.00 log units), on the high side; the range from low to high includes it.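

In this assay, this position on an aromatic nitrogen of a five-membered aromatic ring with 3 nitrogen now has its first readable step, where 2,4,6-trichlorophenyl in place of 2-ethoxyphenyl gives a 1.2-fold higher number from compound 2 to compound 3 (0.09 log units; within the scatter). The two groups share the count of 9 heavy atoms and one six-membered aromatic ring of carbon only but differ in their other atoms, chlorine in one and oxygen in the other, and this exchange does not separate them in the read-out. Compound 1 is reported only as a limit of the assay, and that limit remains part of the set: the limit of > 50000 nM in this assay, at which 1 of the 3 values shown sits.

Still open, from the compounds shown here alone, is whether any group at this position moves the number beyond the scatter, for example a plain methyl, or a phenyl carrying a dimethylamino group or a carboxylic acid. Going by these compounds, the step also rests on a single pair of compounds, so how the same exchange reads on another core or in another cell line remains unknown.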